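This account rests on a few compounds, and the source may have more. Where it says the series, first, only, none or still open, it means among the compounds named here.

Compound 3 `O=C(/C=C/c1ccccc1)N[C@@H](CCCCCC(=O)NO)C(=O)Nc1cccc2cccnc12` is one of three hydroxamic acids tested in a functional assay on NFF cells (Homo sapiens) for antiproliferative activity; a lower number here means a stronger inhibitor, a higher number a weaker inhibitor. In that assay compound 3 gives 1240 nM, the second highest of the three numbers. For the measured compounds named here, compound 2 `CN(C)c1ccc(C(=O)N[C@@H](CCCCCC(=O)NO)C(=O)Nc2cccc3cccnc23)cc1` gives 570 nM, and the change a 2.2-fold higher number from compound 2 to compound 3 (0.34 log units; beyond the scatter) is the one step between measured compounds that shares a place with the step now followed. Compound 1 `O=C(CCCCC[C@H](NC(=O)OCc1ccccc1)C(=O)Nc1ccc(-c2ccccc2)cc1)NO` gives 2200 nM, which lies within the scatter of the value of compound 3.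

Compound 4 `O=C(CCCCC[C@H](NC(=O)OCc1ccccc1)C(=O)Nc1cccc2cccnc12)NO` differs from compound 3 at the same carbonyl carbon: benzyloxy in place of 2-phenylethenyl on a carbonyl carbon. Going by the values given here, no measured step covers this exchange. Among the compounds with values here, compound 1 already carries the benzyloxy group entering here, and its value sits close to that of compound 3, while the one step at this carbonyl was only modest. The expected step of a 1.0-fold higher number from compound 3 to compound 4 (0.02 log units; within the scatter) is therefore within the scatter, with no clear direction. Compound 4 is estimated at 1300 nM, in a range from 500 nM to 3200 nM.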

Compound 4, half-maximal inhibitory concentration: 452 nM
Compound 4: the middle estimate sits 2.9-fold (0.46 log units) above what was measured; measured number below the stated range.
By their numbers in this assay, from the lowest: compounds 4 and 2 (each within the scatter of the next); then compounds 3 and 1 (each within the scatter of the next).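

In this assay, for the compounds shown here, the group on this carbonyl carbon matters more than the single earlier step could show. Benzyloxy in place of 2-phenylethenyl gives a 2.7-fold lower number from compound 3 to compound 4 (0.44 log units; beyond the scatter), while benzyloxy in place of 4-(dimethylamino)phenyl gives a 1.3-fold lower number from compound 2 to compound 4 (0.10 log units; within the scatter), so these two groups cannot be told apart on the shared core and 2-phenylethenyl alone stands apart from both. With benzyloxy held constant, quinolin-8-yl in place of 4-phenylphenyl on an amide-type nitrogen gives a 4.9-fold lower number from compound 1 to compound 4 (0.69 log units; beyond the scatter), so the high number of compound 1 cannot be read as a mark of benzyloxy.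

As far as these compounds go, whether an amine or a carboxylic acid on this carbonyl carbon would match benzyloxy, and whether the quinolin-8-yl step holds with other groups there, remains open. No measurement offered here accounts for these differences.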